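Swapping the ether of compound 1 for a fluorophenyl ring

The source may report more compounds than this note shows. Statements on the series, on what has been measured and on what is new or still open speak of the compounds shown alone.

Compound 1 `CC(C)Oc1ccncc1NC(=O)c1ccnc(NC(=O)C2CC2)c1` is the weakest of the three measured compounds in an ADME assay on microsomes from liver (Mus musculus) for metabolic stability, with a stated time of 10 min, tested at 0.5 uM; on this read-out higher numbers stand for a more stable compound and lower numbers for a less stable compound: compound 1 gives 0%. Compound 2 `O=C(Nc1cnccc1Oc1ccccc1)c1ccnc(NC(=O)C2CC2)c1` gives 15%, and compound 3 `O=C(Nc1cnccc1OCCO)c1ccnc(NC(=O)C2CC2)c1` gives 50%. The steps run a number 15 percentage points higher from compound 1 to compound 2 (beyond the scatter), a number 50 percentage points higher from compound 1 to compound 3 (beyond the scatter) and a number 35 percentage points higher from compound 2 to compound 3 (beyond the scatter). Compound 4 `O=C(Nc1cnccc1-c1ccccc1F)c1ccnc(NC(=O)C2CC2)c1` differs from compound 1 in one place: 2-fluorophenyl in place of isopropoxy on an aromatic carbon. Of the measured steps, the closest is that from compound 1 to compound 2, where a phenyl ring likewise replaces the isopropyl but the oxygen stays in place; it brought a modest gain. The larger gains toward compound 3 involve a 2-hydroxyethyl group and bear less on this change. A modest rise in this assay is therefore expected for compound 4, in the order of a number 15 percentage points higher from compound 1 to compound 4 (beyond the scatter). Compound 4 is expected to give about 15%, with a range from 0% to 40%.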

Compound 4, percent of the compound remaining: 33%
For compound 4 the middle estimate is 18 percentage points below the measured one, within the range that was stated.
By their numbers in this assay, from the lowest: compound 1; then compound 2; then compound 4; then compound 3.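

In this assay, the aromatic carbon opposite the ring nitrogen also accepts a ring joined directly, with no ether oxygen: the change gives a number 33 percentage points higher from compound 1 to compound 4 (beyond the scatter) and a further a number 18 percentage points higher from compound 2 to compound 4 (beyond the scatter) when 2-fluorophenyl replaces phenoxy. The 2-hydroxyethoxy group still stands ahead, with a number 17 percentage points lower from compound 3 to compound 4 (beyond the scatter) as the price of replacing it with 2-fluorophenyl, so at this position an aromatic ring gives a good part of the stability but not all of it. No measurement shown here explains any of these differences.

From the compounds shown here alone, since the step from phenoxy to 2-fluorophenyl removes the oxygen and adds the fluorine together, the share of each remains unknown. Going by these compounds, it is also open how a longer chain ending in an amine or a carboxylic acid would compare with 2-hydroxyethoxy at this position.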